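Cyclic amide regained: a sulfone ring replaces the methoxycyclohexylamine

A few compounds are considered here, and "the series" means these few. Any claim that something is new, unique, unknown or untested is made for them only; others in the source may bear on it.

Three compounds share one core. In a functional assay on MIA PaCa-2 cells (Homo sapiens) for inhibition, read by MTT assay, with a stated time of 3 days (a higher number here means a weaker inhibitor, a lower number a stronger inhibitor), compound 1 `CCN(CC)S(=O)(=O)c1ccc(S(=O)(=O)N2CCC[C@@H](C(=O)N3CCC(OC)CC3)C2)cc1` gives 50 nM and compound 2 `CCN(CC)S(=O)(=O)c1ccc(S(=O)(=O)N2CCC[C@@H](C(=O)N3CCC(COC)CC3)C2)cc1` gives 50 nM; the step of no change at the digits printed from compound 1 to compound 2 (within the scatter). Compound 3 `CCN(CC)S(=O)(=O)c1ccc(S(=O)(=O)N2CCC[C@@H](C(=O)N[C@H]3CC[C@@H](OC)CC3)C2)cc1`, the secondary amide, gives 590 nM in this assay, the highest number of the three, after the steps of a 12-fold higher number from compound 1 to compound 3 (1.07 log units; beyond the scatter) and a 12-fold higher number from compound 2 to compound 3 (1.07 log units; beyond the scatter). Compound 4 `CCN(CC)S(=O)(=O)c1ccc(S(=O)(=O)N2CCC[C@@H](C(=O)N3CCS(=O)(=O)CC3)C2)cc1` differs from compound 3 by 1,1-dioxothiomorpholin-4-yl in place of (4-methoxycyclohexyl)amino on a carbonyl carbon. Going by these compounds, both steps onto compound 3 show that opening the cyclic tertiary amide into an aminocyclohexyl amide cost much; compound 4 returns to a cyclic tertiary amide, so a large drop in number, a 5.9-fold lower number from compound 3 to compound 4 (0.77 log units; beyond the scatter), is expected, though the sulfone ring is untested here. Compound 4 is estimated at 100 nM, expected between 30 nM and 400 nM.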

Compound 4, half-maximal inhibitory concentration: 220 nM
Compound 4: middle estimate off by 2.2-fold (0.34 log units), on the low side, within the range that was stated.
By their numbers in this assay, from the lowest: compounds 1 and 2 (each within the scatter of the next); then compound 4; then compound 3.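

In this assay the cyclic tertiary amide of compound 4 recovers only part of the gap opened by the secondary amide of compound 3 (a 2.7-fold lower number from compound 3 to compound 4 (0.43 log units; beyond the scatter)), and it stays short of both methoxy-bearing rings (a 4.4-fold higher number from compound 1 to compound 4 (0.64 log units; beyond the scatter); a 4.4-fold higher number from compound 2 to compound 4 (0.64 log units; beyond the scatter)). A cyclic tertiary amide on this carbonyl carbon is therefore not enough on its own to reach the numbers of compound 1 and compound 2, and what the ring carries also counts. Nothing measured here gives a reason for this gap.

Where a plain morpholin-4-yl ring, or a piperidin-1-yl ring bearing a hydroxyl or a primary amine, would fall remains open.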